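The compounds below may be only part of what the source reports. "The series", "measured", "known", "first", "only" and "open" are said of these compounds alone.

Measured compounds: compound 1 `CCOC(=O)c1cc(-c2cc(OC)c(OC)c(OC)c2)c(-c2ccc(OC)cc2)s1`, 13200 nM; compound 2 `COc1ccc(-c2sccc2-c2cc(OC)c(OC)c(OC)c2)cc1`, 8880 nM.

Among the compounds with values here, in a functional assay on KB cells (Homo sapiens) for antiproliferative activity, read by MTT assay, with a stated time of 72 h (a higher number here means a weaker inhibitor, a lower number a stronger inhibitor), compound 2 stands lowest of the two numbers, yet its only neighbour is compound 1, and a 1.5-fold lower number from compound 1 to compound 2 (0.17 log units; within the scatter), so the two cannot be told apart. Compound 3 `COc1ccc(-c2sccc2-c2cc(OC)c(OC)c(OC)c2)cc1O` differs from compound 2 by hydroxy in place of hydrogen on an aromatic carbon. Within the data shown here, no measured step involves a hydroxy group; the single known step, a 1.5-fold lower number from compound 1 to compound 2 (0.17 log units; within the scatter), concerns a different group and does not bear on this change. Among the measured compounds shown here, with no relevant step, nothing beyond the scatter is expected in this assay. Compound 3 is therefore estimated at 6000 nM, within 1500 nM to 20000 nM, meaning a 1.5-fold lower number from compound 2 to compound 3 (0.17 log units; within the scatter).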

Compound 3, half-maximal inhibitory concentration: 6270 nM
The estimate for compound 3 lay 1.0-fold (0.02 log units) below the measured number; the measured number falls inside the stated range.
By their numbers in this assay, from the lowest: compounds 3, 2 and 1 (each within the scatter of the next, the first and the last beyond it).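

In this assay, the first change shown on the aromatic ring of carbon only, hydroxy in place of hydrogen ortho to a methoxy group, gives a 1.4-fold lower number from compound 2 to compound 3 (0.15 log units; within the scatter). At this position, then, adding a hydroxy group leaves compound 2 and compound 3 indistinguishable. Nothing measured here bears on why this is so.

On these data alone, whether an amine or a longer alkoxy chain at this position would shift the number beyond the scatter remains open. So does whether hydroxy would have the same outcome on the core of compound 1.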